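Ester to cyclopropyl amide on the acrylate arm

The compounds below may be only part of what the source reports. "The series", "measured", "known", "first", "only" and "open" are said of these compounds alone.

Measured so far:
compound 1 `COC1CN(C(=O)/C=C/c2ccncc2-c2ccc3ccccc3c2)C1`, > 10000 nM
compound 2 `O=C(O)CCc1ccncc1-c1ccc2ccccc2c1`, > 10000 nM
compound 3 `COC(=O)/C=C/c1ccncc1-c1ccc2ccccc2c1`, 760 nM

Going by the values given here, in a functional assay on A549 cells (Homo sapiens) for inhibition, read by sulforhodamine B assay, with a stated time of 72 h (on this read-out higher numbers stand for weaker inhibition of growth and lower numbers for stronger inhibition of growth), compound 3 is the only member of the set that returns a number; the other two return a limit. For compound 1 the value > 10000 nM is a limit of the assay, not a number. For compound 2 likewise > 10000 nM is a limit. The two steps onto compound 3 are both large: an at least 13-fold lower number from compound 1 to compound 3 (1.11 log units; beyond the scatter) and an at least 13-fold lower number from compound 2 to compound 3 (1.11 log units; beyond the scatter), both resting on (the limit of > 10000 nM in this assay, at which 2 of the 3 values shown sit).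

Compound 4 `O=C(/C=C/c1ccncc1-c1ccc2ccccc2c1)NC1CC1` is not yet measured. It differs from compound 3 in one place: cyclopropylamino in place of methoxy on a carbonyl carbon. Among the compounds with values here, the step that bears on this change is the one from compound 1, where an amide on the same carbonyl carbon sat at the limit and the methyl ester of compound 3 gave a far lower number, an at least 13-fold lower number from compound 1 to compound 3 (1.11 log units; beyond the scatter). Returning to an amide, now cyclopropylamino, is therefore expected to move the number back up, and a large step is expected. For compound 4 the expected value in this assay is 6000 nM, with a range from 1500 nM to 20000 nM, meaning an expected step of a 7.9-fold higher number from compound 3 to compound 4 (0.90 log units; beyond the scatter).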

Compound 4, concentration for 50% growth inhibition: 5840 nM
Beside the measured number, compound 4's estimate is 1.0-fold (0.01 log units) above it; low and high end bracket the measured number.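

Compound 4 gives an amide on this carbonyl carbon a number in this assay, so the cost of leaving the methyl ester can now be sized: a 7.7-fold higher number from compound 3 to compound 4 (0.89 log units; beyond the scatter). The cyclopropylamino group returns a number in compound 4, whereas compound 1, also an amide at this carbon, sits at a limit of the assay. The other two steps, an at least 1.7-fold lower number from compound 1 to compound 4 (0.23 log units; that floor lies within the scatter) and an at least 1.7-fold lower number from compound 2 to compound 4 (0.23 log units; that floor lies within the scatter), give only floors and rest on a limit: the limit of > 10000 nM in this assay, at which 2 of the 4 values shown sit.

From the compounds shown here alone, it remains open whether the ester result is specific to methoxy or extends to ethoxy or tert-butoxy on the same carbonyl carbon, and whether a smaller amide such as methylamino behaves like cyclopropylamino. A carboxylic acid on the intact ethenyl chain would separate the acid from the saturated chain, which compound 2 combines.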